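Triazole aryl variation on the shared core

A few compounds are considered here, and "the series" means these few. Any claim that something is new, unique, unknown or untested is made for them only; others in the source may bear on it.

compound 1 `CC1(C)[C@H]2CC[C@]1(C)N(Cc1cn(-c3ccccc3Br)nn1)C(=O)C2`: 280 nM
compound 2 `CC1(C)[C@H]2CC[C@]1(C)N(Cc1cn(-c3ccc(F)cc3)nn1)C(=O)C2`: 110 nM
compound 3 `Cc1ccccc1-n1cc(CN2C(=O)C[C@@H]3CC[C@@]2(C)C3(C)C)nn1`: 250 nM

In a functional assay on PANC-1 cells (Homo sapiens) for inhibition, read by MTT assay, with a stated time of 24 h (a lower number here means a stronger inhibitor, a higher number a weaker inhibitor), compound 1 gives 280 nM, the highest of the three numbers; compound 3 stands nearest, with a 1.1-fold lower number from compound 1 to compound 3 (0.05 log units; within the scatter), and compound 2 furthest, with a 2.5-fold lower number from compound 1 to compound 2 (0.41 log units; beyond the scatter). Compound 4 `CC1(C)[C@H]2CC[C@]1(C)N(Cc1cn(-c3ccc(Cl)cc3)nn1)C(=O)C2` differs from compound 1 by 4-chlorophenyl in place of 2-bromophenyl on an aromatic nitrogen. The step that bears on this most is a 2.5-fold lower number from compound 1 to compound 2 (0.41 log units; beyond the scatter), where 2-bromophenyl likewise gave way to a halogen-bearing 4-substituted phenyl; a 1.1-fold lower number from compound 1 to compound 3 (0.05 log units; within the scatter) shows that methyl in place of bromo on the aromatic carbon alone changes little. A modest lowering of the same order is therefore expected for compound 4, a 2.2-fold lower number from compound 1 to compound 4 (0.33 log units; beyond the scatter), with the estimate for compound 4 at 130 nM and a range from 60 nM to 300 nM.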

Compound 4, half-maximal inhibitory concentration: 440 nM
Estimate against measurement, compound 4: 3.4-fold (0.53 log units) below; measured number outside the range, above it.
By their numbers in this assay, from the lowest: compound 2; then compounds 3, 1 and 4 (each within the scatter of the next).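

With the aryl group kept as a 4-substituted phenyl on the aromatic nitrogen, chloro in place of fluoro gives a 4.0-fold higher number from compound 2 to compound 4 (0.60 log units; beyond the scatter), so the lower number of compound 2 does not extend to every 4-halophenyl group. The 4-chlorophenyl group does not separate from the 2-bromophenyl or 2-methylphenyl groups: a 1.6-fold higher number from compound 1 to compound 4 (0.20 log units; within the scatter) and a 1.8-fold higher number from compound 3 to compound 4 (0.25 log units; within the scatter) both lie within the scatter. Among these aryl groups, only 4-fluorophenyl stands apart, and on one compound.

Going by these compounds, whether 4-methoxyphenyl or 4-aminophenyl would side with compound 2 or compound 4 stays open. No data at hand speak to why fluoro and chloro differ here.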